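The source may hold more compounds than are shown below. What is called first, only, known or untested is meant among the compounds shown, and "the series" means these compounds.

Measured in an ADME assay on MT4 cells (Homo sapiens) for cytotoxicity, read by MTT assay, with a stated time of 3 days; a lower number here means that less compound is tolerated, a higher number that more compound is tolerated:

Compound 1 `O=C(COC(=O)c1ccc([N+](=O)[O-])o1)NCC1CCCO1`: > 100000 nM
Compound 2 `CC(C)(C)N(CCCc1ccccc1)C(=O)COC(=O)c1ccc([N+](=O)[O-])o1`: "not active" (no number reported)
Compound 3 `CC(C)(C)N(CCC(=O)c1ccccc1)C(=O)COC(=O)c1ccc([N+](=O)[O-])o1`: "not active" (no number reported)

Compound 3 has no single number on this read-out, and it is reported only as "not active" (no number reported) in this assay. Compound 2 carries the same kind of entry, "not active" (no number reported), so it too offers no figure to compare. Compound 1 stands at > 100000 nM, and this is a limit and not a number. The three compounds therefore give no measured value, and none of them can be ranked against another.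

Compound 4 `CC(C)(C)N(Cc1ccc([N+](=O)[O-])cc1)C(=O)COC(=O)c1ccc([N+](=O)[O-])o1` has not yet been measured. The change is 4-nitrophenyl in place of benzoylmethyl on a saturated chain carbon bound to an amide-type nitrogen and, in words, it sets 4-nitrophenyl in place of benzoylmethyl on a saturated chain carbon bound to an amide-type nitrogen.

No measured step links any of these compounds, so the data give no size for such a change. The expectation is no shift beyond the usual scatter, and any shift that does come is expected toward less compound being tolerated. This expectation rests on compound 3 with its entry of "not active" (no number reported) in this assay. For compound 4 the estimated half-maximal cytotoxic concentration is 60000 nM as a middle value, with an expected range from 15000 nM to 100000 nM in this assay.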

Compound 4, half-maximal cytotoxic concentration: > 100000 nM
Compound 4: a limit, no number; the forecaster's own chance of this, stated with the estimate: 55%; middle value at least 1.6-fold (0.22 log units) away from the limit.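

In this assay compound 4 gives > 100000 nM, which is a limit and not a number. Compound 3 is entered only as "not active", so no step can be read between compound 3 and compound 4. The results end at a shared ceiling: the limit of > 100000 nM in this assay, at which 2 of the 4 values shown sit.

The compounds shown leave open whether replacing benzoylmethyl with 4-nitrophenyl changes how much compound is tolerated.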